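Ethoxycarbonyl in place of 3-fluorophenyl on the triazole carbon

The compounds below may be only part of what the source reports. "The series", "measured", "known", "first", "only" and "open" are said of these compounds alone.

Measured so far, in an ADME assay on HeLa cells (Homo sapiens) for cytotoxicity, read by sulforhodamine B assay, with a stated time of 48 h, tested at 10 uM; a higher number here means more inhibition at the concentration tested (going by the name of the read-out), a lower number less inhibition:
- compound 1, `CCCCCCCc1cn(C(c2ccccc2)c2cc3cc(Br)ccc3nc2OC)nn1`: compound 1 gives 9.7%
- compound 2, `COc1nc2ccc(Br)cc2cc1C(c1ccccc1)n1cc(-c2cccc(F)c2)nn1`: compound 2 gives 9.04%
- compound 3, `COc1nc2ccc(Br)cc2cc1C(c1ccccc1)n1cc(CCCCCO)nn1`: compound 3 gives 1.08%

Compound 2 stands second highest of the three numbers; its nearest neighbour is compound 1, and its furthest is compound 3, and both gaps lie within the scatter, so no order among the three can be read from them.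

Compound 4, `CCOC(=O)c1cn(C(c2ccccc2)c2cc3cc(Br)ccc3nc2OC)nn1`, is not yet measured. It differs from compound 2 in one place: ethoxycarbonyl in place of 3-fluorophenyl on an aromatic carbon.

Within the data shown here, two measured steps bear on this change, both at the same aromatic carbon of the shared core. The step of a number 0.7 percentage points lower from compound 1 to compound 2 (within the scatter) and the step of a number 8 percentage points lower from compound 2 to compound 3 (within the scatter) both stay within the scatter, although the groups swapped there differ widely: a heptyl chain, a 3-fluorophenyl ring and a 5-hydroxypentyl chain. The third step, a number 8.6 percentage points lower from compound 1 to compound 3 (within the scatter), is also within the scatter. Nothing in these three compounds shows that the group at this position moves the read-out beyond the scatter.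

For compound 4 the step of a number 2 percentage points lower from compound 2 to compound 4 (within the scatter) is therefore expected to stay within the scatter. Compound 4 is estimated to give 7%, with a range from 0% to 17%.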

Compound 4, a percentage reported as inhibition, at one concentration (the size of the read-out at that concentration, not a potency): -3.67%
Beside the measured number, compound 4's estimate is 10.7 percentage points above it; measured number below the stated range.
By their numbers in this assay, from the lowest: compounds 4, 3, 2 and 1 (each within the scatter of the next, the first and the last beyond it).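

In this assay, the group on this aromatic carbon of the five-membered aromatic ring can shift the read-out beyond the scatter, which the earlier compounds had not shown: ethoxycarbonyl in place of 3-fluorophenyl gives a number 12.7 percentage points lower from compound 2 to compound 4 (beyond the scatter), and ethoxycarbonyl in place of heptyl gives a number 13.4 percentage points lower from compound 1 to compound 4 (beyond the scatter). The same group set against 5-hydroxypentyl gives a number 4.8 percentage points lower from compound 3 to compound 4 (within the scatter), so the shift does not hold against every group at this position. Nothing measured here accounts for these steps.

From the compounds shown here alone, it remains open whether a carboxylic acid, an amide or a methyl ester at this carbon would read like ethoxycarbonyl. With only one tested concentration, these steps also leave open how the compounds would compare across a range of concentrations.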